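The compounds below may be only part of what the source reports. "The series", "measured", "known", "first", "only" and "open" are said of these compounds alone.

Measured so far in a functional assay on DU-145 cells (Homo sapiens) for inhibition, read by trypan blue exclusion, with a stated time of 96 h; a lower number here means a stronger inhibitor of growth, a higher number a weaker inhibitor of growth:
compound 1 `Cc1ccc(/C=C(\C(=O)c2ccc(Cl)cc2)S(=O)(=O)Cc2ccc(Cl)cc2)s1` gives 1000 nM
compound 2 `Cc1cc(C)cc(/C=C(\C(=O)c2ccc(Cl)cc2)S(=O)(=O)Cc2ccc(Cl)cc2)c1` gives 1000 nM
compound 3 `COc1ccccc1/C=C(\C(=O)c1ccc(Cl)cc1)S(=O)(=O)Cc1ccc(Cl)cc1` gives 25000 nM

Compound 2 stands level with compound 1, the two together holding the lowest numbers of the three; no change at the digits printed from compound 1 to compound 2 (within the scatter). Compound 3 is the one that falls away: a 25-fold higher number from compound 2 to compound 3 (1.40 log units; beyond the scatter), and likewise a 25-fold higher number from compound 1 to compound 3 (1.40 log units; beyond the scatter). All three of these measured steps exchange the aryl group on the double-bonded chain carbon, so they describe only that end of the shared core and say nothing about the group carried by the sulfonyl sulfur, which is the same 4-chlorobenzyl in compounds 1, 2 and 3.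

Compound 4 `Cc1ccc(S(=O)(=O)/C(=C/c2cc(C)cc(C)c2)C(=O)c2ccc(Cl)cc2)cc1` differs from compound 2 at exactly that untested position: 4-methylphenyl in place of 4-chlorobenzyl on a sulfonyl sulfur. For the measured compounds named here, no measured step bears on this change, so there is no precedent from which to read a direction or a size. The working expectation is therefore a step within the scatter from compound 2 to compound 4, estimated as no change at the digits printed from compound 2 to compound 4 (within the scatter), with the range set wide for lack of any comparison at the sulfonyl sulfur. Compound 4 is estimated to give 1000 nM in this assay, within 250 nM to 6000 nM.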

Compound 4, concentration for 50% growth inhibition: 1000 nM
Beside the measured number, compound 4's estimate shows no gap at the digits printed; low and high end bracket the measured number.
By their numbers in this assay, from the lowest: compounds 1, 2 and 4 (each within the scatter of the next); then compound 3.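

In this assay, the group on the sulfonyl sulfur now has its first comparison: 4-methylphenyl in place of 4-chlorobenzyl reads as no change at the digits printed from compound 2 to compound 4 (within the scatter). For the compounds shown here, on the 3,5-dimethylphenyl background, this position therefore accepts an exchange that removes the chlorine and alters the group from 8 to 7 heavy atoms, with a six-membered aromatic ring of carbon only present in both groups, and the earlier steps at the aryl end gave no view of this. Nothing available explains the result, and this single pair cannot separate the contribution of the chlorine from that of the rest of the exchange.

Still open, from the compounds shown here alone, is whether the same reading holds on the other aryl backgrounds, especially the 2-methoxyphenyl of compound 3, which carries the 4-chlorobenzyl group and gives 25000 nM in this assay. Also open, going by these compounds, is how the series responds when the sulfonyl sulfur carries something quite different from these two groups, such as a carboxylic acid, an amine or a longer alkyl chain.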